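Fluoro Addition on the Triazole-Linked Phenyl of a Sulfonamide Series

This account rests on a few compounds, and the source may have more. Where it says the series, first, only, none or still open, it means among the compounds named here.

Measured so far:
compound 1, `Cc1ccc(-n2cc(-c3cccc(NS(=O)(=O)c4c[nH]c(=O)[nH]c4=O)c3)nn2)cc1`, 3630 nM
compound 2, `O=c1[nH]cc(S(=O)(=O)Nc2ccc(-c3cn(-c4ccccc4)nn3)cc2)c(=O)[nH]1`, 7170 nM

Both compounds were tested in a functional assay on A549 cells (Homo sapiens) for antiproliferative activity, read by MTT assay, with a stated time of 24 h; on this read-out lower numbers stand for stronger inhibition and higher numbers for weaker inhibition. Compound 1 gives 3630 nM and compound 2 gives 7170 nM. Of the two numbers, compound 2 carries the numerically larger one, but the gap to compound 1 lies within the usual scatter of this assay, so the two cannot be told apart on these data. Going by the values given here, no step between compounds that differ in a single place has been measured.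

Compound 3, `O=c1[nH]cc(S(=O)(=O)Nc2ccc(-c3cn(-c4ccc(F)cc4)nn3)cc2)c(=O)[nH]1`, is not yet measured. It differs from compound 2 by fluoro in place of hydrogen on an aromatic carbon. Among the compounds with values here, with no measured single-point step available, the size of the change can only be judged from the change itself, which adds a single fluorine on the phenyl that sits on the triazole. For compound 3 the expected step is a 1.2-fold lower number from compound 2 to compound 3 (0.08 log units; within the scatter), that is, no movement beyond the scatter in either direction. Compound 3 is therefore estimated at 6000 nM in this assay, with a range from 2500 nM to 15000 nM.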

Compound 3, half-maximal inhibitory concentration: 9720 nM
The estimate for compound 3 lay 1.6-fold (0.21 log units) below the measured number, within the range that was stated.
By their numbers in this assay, from the lowest: compounds 1, 2 and 3 (each within the scatter of the next, the first and the last beyond it).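

In this assay, the series now has its first step between compounds that differ in one place: a 1.4-fold higher number from compound 2 to compound 3 (0.13 log units; within the scatter). Replacing hydrogen with fluoro on an aromatic carbon para to a large group, which turns phenyl into 4-fluorophenyl, therefore leaves compound 3 indistinguishable from compound 2 on this read-out, so this position accepts this single-atom change with no readable shift in either direction. Nothing available bears on what lies behind this outcome.

Going by these compounds alone, the single step covers only hydrogen and fluoro at this one place, so it remains open whether a different group there, such as an amine, a carboxylic acid or a methoxy group, would move the number beyond the scatter. Going by these compounds, it also remains open whether the same fluoro change would read alike on the core of compound 1, and one step gives no basis for extending this result to any other position or compound.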